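Methoxy on a weaker chain-lengthened core

The source may hold more compounds than are shown below. What is called first, only, known or untested is meant among the compounds shown, and "the series" means these compounds.

Measured compounds:
compound 1 `CC1(C)CCCN(CCCCC2CCCc3ccccc32)C1` 0.69 nM
compound 2 `COc1ccc2c(c1)CCCC2CCCCN1CCCC(C)(C)C1` 2150 nM
compound 3 `CC1(C)CCCN(CCCCCC2CCCc3ccccc32)C1` 1520 nM

In an assay on cell membranes for binding affinity to Sigma non-opioid intracellular receptor 1 (Rattus norvegicus), read by radioligand binding (a lower number here means a stronger inhibitor, a higher number a weaker inhibitor), compound 1 gives 0.69 nM. The change to compound 2, (methoxy in place of hydrogen on an aromatic carbon), made a large step: a 3100-fold higher number from compound 1 to compound 2 (3.49 log units; beyond the scatter). Compound 3 `CC1(C)CCCN(CCCCCC2CCCc3ccccc32)C1` gives 1520 nM; the difference between its core and the core of compound 1 is not broken down here, and its value stands within the scatter of compound 2.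

Compound 4 `COc1ccc2c(c1)CCCC2CCCCCN1CCCC(C)(C)C1` has not yet been measured. It differs from compound 3 by methoxy in place of hydrogen on an aromatic carbon, the same change as from compound 1 to compound 2 in the same place. The earlier step was large, but compound 3 starts from a far higher number than compound 1, so a step as large as a 3100-fold higher number from compound 1 to compound 2 (3.49 log units; beyond the scatter) may not be repeated; the expected step is a 5.3-fold higher number from compound 3 to compound 4 (0.72 log units; beyond the scatter). In this assay compound 4 is expected to give 8000 nM, with the estimate ranging from 1500 nM to 50000 nM, and a real chance that only a limit is reported.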

Compound 4, half-maximal inhibitory concentration: 0.62 nM
Compound 4: middle estimate off by 13000-fold (4.11 log units), on the high side; the measured number lies below the stated range.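

In this assay, methoxy in place of hydrogen on an aromatic carbon gave a 2500-fold lower number from compound 3 to compound 4 (3.39 log units; beyond the scatter), so the change that weakened binding on the core of compound 1 strengthened it on the core of compound 3. Among the compounds shown here, in this series the effect of the change therefore cannot be carried from one core to the other, not even in its direction: the same change on two cores in this assay, a 3100-fold higher number (3.49 log units; beyond the scatter) from compound 1 to compound 2 and a 2500-fold lower number (3.39 log units; beyond the scatter) from compound 3 to compound 4, 7600000-fold (6.88 log units) apart, beyond the scatter of two such steps This rests on only two pairs in a single assay, and it does not show why the direction reverses or how the change would behave on any further core.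

The compounds shown leave open whether another group in the same place, such as hydroxyl or fluorine, would reverse in the same way between these two cores. Also open, on these data alone, is how methoxy would act with a chain shorter than that of compound 1 or longer than that of compound 3.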